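The compounds below may be only part of what the source reports. "The series", "measured", "known", "first", "only" and "open" are said of these compounds alone.

Working notes on the series.

Two compounds carry the shared core with a urea-linked aryl tail; they have been measured in a functional assay on NCI-H522 cells (Homo sapiens) for inhibition, read by sulforhodamine B assay, with a stated time of 48 h; a lower number here means a stronger inhibitor of growth, a higher number a weaker inhibitor of growth. Compound 1 `O=C(Nc1cccc(-n2cc(-c3ccncc3)c(-c3ccc(Cl)c(O)c3)n2)c1)Nc1cccc(C(F)(F)F)c1` gives 14500 nM in this assay. Compound 2 `COc1cc(-c2nn(-c3cccc(NC(=O)Nc4ccc(Cl)c(C(F)(F)F)c4)c3)cc2-c2ccncc2)ccc1Cl` gives 6060 nM in this assay, the lowest of the two numbers, and the gap to compound 1 lies beyond the scatter. The two differ in more than one place, so only their values are stated here.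

Compound 3 `O=C(Nc1cccc(-n2cc(-c3ccncc3)c(-c3ccc(Cl)c(O)c3)n2)c1)Nc1ccc(Cl)c(C(F)(F)F)c1` has not been measured in this assay. It differs from compound 2 in that (hydrogen in place of methyl on an oxygen on an aromatic ring); its urea tail is that of compound 2, its phenyl with the free hydroxy that of compound 1. For the measured compounds named here, no measured pair isolates this change. The expected step from compound 2 to compound 3 is a 1.5-fold higher number from compound 2 to compound 3 (0.17 log units; within the scatter), a modest shift toward weaker growth inhibition that may well sit within the scatter. Compound 3 is therefore expected to give about 9000 nM in this assay, with a range from 3000 nM to 27000 nM.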

Compound 3, concentration for total growth inhibition: 2500 nM
For compound 3 the middle estimate is 3.6-fold (0.56 log units) above the measured one; measured number outside the range, below it.
By their numbers in this assay, from the lowest: compound 3; then compound 2; then compound 1.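

In this assay, for the compounds shown here, methoxy to hydroxy on the 4-chloro phenyl gives a 2.4-fold lower number from compound 2 to compound 3 (0.38 log units; beyond the scatter), the first reading of this change on its own; with this urea tail, the free hydroxy goes with stronger growth inhibition than the methoxy. Going by these compounds alone, the same compound also gives the first single-place reading on the urea tail, where chloro in place of hydrogen on an aromatic carbon gives a 5.8-fold lower number from compound 1 to compound 3 (0.76 log units; beyond the scatter), a larger step than the one at the oxygen. No measurement on hand accounts for either step.

Going by these compounds, both steps rest on a single pair each, so whether the hydroxy step carries over to the tail of compound 1 remains open. Also open, on these data alone, is how an ethoxy group or an amino group in place of the hydroxy would read in this assay.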